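Swapping Methylsulfonyl for Hydroxy on the Chain

This account rests on a few compounds, and the source may have more. Where it says the series, first, only, none or still open, it means among the compounds named here.

Compound 1 `CS(=O)(=O)CCCn1c(Cn2nc(S(C)(=O)=O)c3ccncc32)nc2cc(Cl)ccc21` was tested in an ADME assay on HEp-2 cells (Homo sapiens) for cytotoxicity, with a stated time of 4 days; a lower number here means that less compound is tolerated, a higher number that more compound is tolerated. In this assay compound 1 gives > 100000 nM, which is a limit of the assay and not a number. Compound 2 `CC(C)S(=O)(=O)c1cn(Cc2nc3cc(Cl)ccc3n2CCCS(C)(=O)=O)c2ccccc12` likewise gives > 100000 nM in this assay, again only a limit. Compound 1 therefore stands at the limit of > 100000 nM in this assay, at which 2 of the 2 values shown sit, where every shown value stands. Compound 3 `CS(=O)(=O)c1nn(Cc2nc3cc(Cl)ccc3n2CCCO)c2cnccc12` differs from compound 1 by hydroxy in place of methylsulfonyl on a saturated chain carbon, three bonds along the chain from an aromatic nitrogen. Going by the values given here, no measured step between two compounds is available, so the size of such a change is unknown. The step of a number no higher from compound 1 to compound 3 (the limit leaves the size open) is expected to stay within the scatter. In this assay compound 3 is estimated at 100000 nM, between 50000 nM and 200000 nM, most probably again reported only as a limit.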

Compound 3, half-maximal cytotoxic concentration: > 100000 nM
Compound 3: only a limit was reported; the forecaster's own chance of this, stated with the estimate: 85%; the middle value lies on the limit itself.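

Going by these compounds alone, compound 1 and compound 3 are both reported only as limits in this assay, and no step between them can be read. The compounds shown leave open whether hydroxy in place of methylsulfonyl changes cytotoxicity at all.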